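Adding a Methyl Group to a Compound at the Limit

The source may report more compounds than this note shows. Statements on the series, on what has been measured and on what is new or still open speak of the compounds shown alone.

Compound 1, `Cc1cc(OC2CCCC2)nc(Nc2ccc(C#N)cc2)n1`: 1050 nM
Compound 2, `N#Cc1ccc(Nc2nccc(SC3CCCCC3)n2)cc1`: > 402000 nM

Both measured compounds were tested in an ADME assay on MT4 cells (Homo sapiens) for cytotoxicity, read by MTT assay; on this read-out higher numbers stand for lower toxicity in this test and lower numbers for higher toxicity in this test. Compound 1 gives 1050 nM in this assay. For compound 2 the result is only a limit, > 402000 nM, not a number. Compound 2 thus sits at the limit of > 402000 nM in this assay, at which 1 of the 2 values shown sits. These two compounds differ in more than one place. Within the data shown here, their values show only that compound 1 registers a number while compound 2 does not.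

Compound 3, `Cc1cc(SC2CCCCC2)nc(Nc2ccc(C#N)cc2)n1`, has not yet been measured. It differs from compound 2 by one change: methyl in place of hydrogen on an aromatic carbon. Among the measured compounds shown here, no measured pair isolates this change, so its effect is unknown. Compound 1 carries a methyl group on its core and gives 1050 nM. Compound 2 lacks it. The expected step is an at least 6.7-fold lower number from compound 2 to compound 3 (0.82 log units; beyond the scatter). Compound 3 is therefore estimated at 60000 nM, with a likely range from 8000 nM to 402000 nM.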

Compound 3, half-maximal cytotoxic concentration: >= 192000 nM
Compound 3: a limit, no number; the forecaster's own chance of this, stated with the estimate: 35%; middle value at least 3.2-fold (0.50 log units) from the limit.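

In this assay compound 3 gives only a limit, not a number: the limit of >= 192000 nM in this assay, at which 1 of the 3 values shown sits. Compound 2 also stands at a limit, so the step for methyl in place of hydrogen cannot be read, and this methyl has no measured size here. The methyl is present in both compound 1 and compound 3, and there cyclohexylsulfanyl in place of cyclopentyloxy gives an at least 180-fold higher number from compound 1 to compound 3 (2.26 log units; beyond the scatter), so the methyl alone does not bring the shared core down to the value of compound 1.

That swap changes both the linking atom and the ring, and a cyclohexyloxy group at the same place would be needed to tell the two apart. On these data alone, it also remains open how an ethyl group or an amine in place of this methyl would read in this assay.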